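A few compounds are considered here, and "the series" means these few. Any claim that something is new, unique, unknown or untested is made for them only; others in the source may bear on it.

Compound 1, with the structure `O=C1C=COC(/C=C/c2ccccc2)C1`, was tested in an ADME assay on HaCaT cells (Homo sapiens) for inhibition, read by sulforhodamine B assay, with a stated time of 48 h (on this read-out higher numbers stand for weaker inhibition of growth and lower numbers for stronger inhibition of growth), where compound 1 gives 127 uM. Compound 2, `COc1ccc(/C=C/C2CC(=O)C=CO2)cc1`, carries one change relative to compound 1, described as methoxy in place of hydrogen on an aromatic carbon, and in this assay compound 2 gives 145 uM. The resulting step is a 1.1-fold higher number from compound 1 to compound 2 (0.06 log units; within the scatter), so the two compounds cannot be told apart on this read-out.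

Compound 3, `COc1ccc(/C=C/C2CC=CC(=O)O2)cc1`, has a different core; how the core of compound 3 differs from the core of compound 1 is not broken down here. In this assay compound 3 gives 58.8 uM, which is the lowest of the three numbers and beyond the scatter from both compound 1 and compound 2.

Compound 4, `COc1ccc(/C=C/C2CC=CC(=O)O2)cc1OC`, has not yet been measured. Relative to compound 3 it carries the change (methoxy in place of hydrogen on an aromatic carbon). Among the measured compounds shown here, this is the same kind of change as the one from compound 1 to compound 2, but the place is not the same: in compound 2 the new methoxy stands para to a group of 9 heavy atoms, whereas in compound 4 it stands ortho to a methoxy group and meta to a group of 9 heavy atoms.

For the measured compounds named here, because the one measured instance of this kind of change gave a 1.1-fold higher number from compound 1 to compound 2 (0.06 log units; within the scatter), the step from compound 3 to compound 4 is expected to be a 1.0-fold higher number from compound 3 to compound 4 (0.01 log units; within the scatter), with wider uncertainty owing to the different place. Compound 4 is therefore estimated at 60 uM in this assay, expected to fall between 30 uM and 120 uM.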

Compound 4, concentration for growth inhibition (reported as GI): 63 uM
Estimate against measurement, compound 4: 1.1-fold (0.02 log units) below; low and high end bracket the measured number.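

The new step, methoxy in place of hydrogen on an aromatic carbon, is a 1.1-fold higher number from compound 3 to compound 4 (0.03 log units; within the scatter) in this assay, so this change does not separate the two compounds on this read-out. Set beside the earlier step, the change reads the same on the two cores: the same change on two cores in this assay, a 1.1-fold higher number (0.06 log units; within the scatter) from compound 1 to compound 2 and a 1.1-fold higher number (0.03 log units; within the scatter) from compound 3 to compound 4, 1.1-fold (0.03 log units) apart, within the scatter of two such steps. This shows that in these two instances the added methoxy made no readable difference, even though in compound 4 it stands ortho to a methoxy group and meta to a group of 9 heavy atoms; it does not show that the change would stay silent on any other core, at any other place on the ring, or in any other assay, and two pairs set no rule.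

The compounds shown leave open whether a group other than methoxy at this place, such as a hydroxyl, an amine or a carboxylic acid, or a longer chain such as butoxy, would move the number on either core. They also leave open whether a chlorine atom or a nitrile on the same aromatic ring would read alike on the two cores, as methoxy does here.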